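The compounds below may be only part of what the source reports. "The series", "measured", "known", "first", "only" and "open" are said of these compounds alone.

Measured compounds in the series:

- compound 1, `O=S(=O)(c1cc(Cl)cc(Cl)c1)c1cnc2c(F)cccc2c1-c1cccc(Cl)c1`: 1.2 mL/min
- compound 2, `O=S(=O)(c1cccc(F)c1)c1cnc2c(F)cccc2c1-c1cccc(Cl)c1`: 0.56 mL/min
- compound 3, `O=S(=O)(c1cc(Cl)cc(Cl)c1)c1cnc2cc(F)ccc2c1-c1ccc(F)cc1`: 0.18 mL/min

All three numbers come from an ADME assay on microsomes from liver (Homo sapiens) for metabolic stability, tested at 2.5 uM; on this read-out lower numbers stand for slow clearance and higher numbers for fast clearance. Compound 1 and compound 2 share a core and differ in one place: 3-fluorophenyl in place of 3,5-dichlorophenyl on a sulfonyl sulfur. That change gave a 2.1-fold lower number from compound 1 to compound 2 (0.33 log units; beyond the scatter). Compound 3 sits on a different core; how the core of compound 3 differs from the core of compound 1 is not broken down here. Compound 3 has the lowest number of the three in this assay; compound 2 is the nearest to it and compound 1 the furthest, both gaps beyond the scatter.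

Compound 4, `O=S(=O)(c1cccc(F)c1)c1cnc2cc(F)ccc2c1-c1ccc(F)cc1`, has not yet been run in this assay. It stands to compound 3 as compound 2 stands to compound 1, the same change in the same place: 3-fluorophenyl in place of 3,5-dichlorophenyl on a sulfonyl sulfur. Among the compounds with values here, the one earlier occurrence of this change, from compound 1 to compound 2, is the only guide, and it rests on one pair only. Carrying that step over, compound 4 is expected to move from compound 3 by a 2.0-fold lower number from compound 3 to compound 4 (0.30 log units; within the scatter) in this assay, because the measured pair gave a 2.1-fold lower number from compound 1 to compound 2 (0.33 log units; beyond the scatter). Since compound 3 already gives the lowest number, compound 4 is estimated at 0.09 mL/min in this assay, with a range from 0.04 mL/min to 0.2 mL/min, and with some chance that only a limit is reported.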

Compound 4, intrinsic clearance in a liver preparation (reported as CLH), per the amount of preparation that the assay uses: 0.11 mL/min
Compound 4: the middle estimate sits 1.2-fold (0.09 log units) below what was measured, and the stated range covers the measured number.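

In this assay, putting 3-fluorophenyl in place of 3,5-dichlorophenyl on the sulfonyl sulfur gave a 1.6-fold lower number from compound 3 to compound 4 (0.21 log units; within the scatter) and so does not, taken alone, separate this pair. Set beside the earlier step, the change shows no detectable difference in size between the two cores: the same change on two cores in this assay, a 2.1-fold lower number (0.33 log units; beyond the scatter) from compound 1 to compound 2 and a 1.6-fold lower number (0.21 log units; within the scatter) from compound 3 to compound 4, 1.3-fold (0.12 log units) apart, within the scatter of two such steps. This agreement does not establish a general rule: it rests on two pairs, only one of which moves beyond the scatter, and it says neither why the numbers shift nor whether the step would hold on a further core.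

The compounds shown carry only 3,5-dichlorophenyl or 3-fluorophenyl on the sulfonyl sulfur, so the response of this clearance read-out to a group such as an amine, a carboxylic acid or a nitrile in that place remains open. Also open, as far as these compounds go, is whether the same change would keep its size on a core bearing an amine or a longer alkyl chain, since the two cores seen here offer no such case.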